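A Chloro Group Added to Compound 2

This account rests on a few compounds, and the source may have more. Where it says the series, first, only, none or still open, it means among the compounds named here.

Measured in a functional assay on Jurkat cells (Homo sapiens) for cytotoxicity, read by luminescence and CellTiter-Glo, with a stated time of 3 days; a lower number here means a stronger inhibitor, a higher number a weaker inhibitor:
- Compound 1 `O=C(Nc1cc(F)cc(F)c1)c1ccc2cccnc2c1O`: 430 nM
- Compound 2 `O=C(Nc1ccc(OC(F)(F)F)cc1)c1cc(F)ccc1O`: 810 nM
- Compound 3 `N#Cc1ccc(NC(=O)c2ccc(Br)cc2O)cc1Cl`: 750 nM

In this set, compound 2 gives 810 nM. That value lies within the scatter of compound 3 at 750 nM and also within the scatter of compound 1 at 430 nM. The three measured compounds therefore offer no clear separation in this assay.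

Compound 4 `O=C(Nc1ccc(OC(F)(F)F)c(Cl)c1)c1cc(F)ccc1O` departs from compound 2 by one change: chloro in place of hydrogen on an aromatic carbon. For the measured compounds named here, no pair of measured compounds isolates this change, so the data give no direct guide to its size. Compound 3 also carries a chloro group, yet its value of 750 nM does not separate from that of compound 2, so only a modest shift seems reasonable. The expected change is a 1.6-fold lower number from compound 2 to compound 4 (0.19 log units; within the scatter), a small move toward a lower number that may stay within the scatter. For compound 4 the estimated value is 520 nM, with an expected range of 220 nM to 1200 nM.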

Compound 4, half-maximal inhibitory concentration: 700 nM
Beside the measured number, compound 4's estimate is 1.3-fold (0.13 log units) below it; the range from low to high includes it.
By their numbers in this assay, from the lowest: compounds 1, 4, 3 and 2 (each within the scatter of the next).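

In this assay, chloro in place of hydrogen on this aromatic carbon, ortho to a trifluoromethoxy group, gives a 1.2-fold lower number from compound 2 to compound 4 (0.06 log units; within the scatter). For the compounds shown here, this is the first direct reading of the change in the set, and it shows that adding this one chlorine atom at this position produces no shift that can be told from the scatter. Nothing available bears on why the step is this small.

Going by these compounds, whether another group on this same carbon, such as an amine, a methoxy group or a carboxylic acid, would move the number beyond the scatter remains open. Also open, on these data alone, is whether chloro would give a similarly small step on the core of compound 1, or with something other than trifluoromethoxy as its neighbouring group.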